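A Heteroatom-Bearing Ring Returns to the Amine Tail

A few compounds are considered here, and "the series" means these few. Any claim that something is new, unique, unknown or untested is made for them only; others in the source may bear on it.

Compound 2 `CC(C)(N)CCCN(C[C@H]1Cc2ccccc2CN1)[C@H]1CCCc2cccnc21` stands as the lowest of the two numbers recorded in a functional assay on cells for antagonist activity at C-X-C chemokine receptor type 4 (Homo sapiens), read by fluorescence and calcium flux, with stated times of 25 min and 90 s; on this read-out lower numbers stand for stronger inhibition and higher numbers for weaker inhibition: compound 2 gives 24.6 nM, while compound 1 `CC1(C)CCC(NCCCCN(C[C@H]2Cc3ccccc3CN2)[C@H]2CCCc3cccnc32)CC1` gives 77.6 nM. Among the measured compounds shown here, the step of a 3.2-fold lower number from compound 1 to compound 2 (0.50 log units; beyond the scatter) is the only measured step, and it accompanied a group of 4 heavy atoms in place of a group of 10 heavy atoms with one six-membered non-aromatic ring. Compound 3 `CC(C)(CCN(C[C@H]1Cc2ccccc2CN1)[C@H]1CCCc2cccnc21)CNC1CCOCC1` moves the other way: a group of 11 heavy atoms (9 carbon, 1 nitrogen, 1 oxygen; one six-membered non-aromatic ring with 1 hetero atom) in place of a group of 5 heavy atoms (4 carbon, 1 nitrogen; no ring), on a saturated chain carbon, two bonds along the chain from an amine nitrogen. For the measured compounds named here, since the one measured step shows that removing a six-membered ring from the amine tail lowered the number, and compound 3 brings a ring-bearing group back into that tail, a modest rise beyond the scatter is expected, though the shift of the ring further from the amine nitrogen and the added hetero atom leave the size uncertain. Compound 3 is therefore expected to give 50 nM in this assay, in the range 15 nM to 160 nM, corresponding to an expected step of a 2.0-fold higher number from compound 2 to compound 3 (0.31 log units; beyond the scatter).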

Compound 3, half-maximal inhibitory concentration: 36.3 nM
Compound 3: middle estimate off by 1.4-fold (0.14 log units), on the high side, and the stated range covers the measured number.
By their numbers in this assay, from the lowest: compounds 2 and 3 (each within the scatter of the next); then compound 1.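

In this assay the step of a 1.5-fold higher number from compound 2 to compound 3 (0.17 log units; within the scatter) shows that the position on a saturated chain carbon, two bonds along the chain from an amine nitrogen, can carry a group with a six-membered non-aromatic ring with 1 hetero atom in place of 2-amino-2-methylpropyl without leaving the scatter. So a ring in the tail does not in itself raise the number, which the earlier step alone could not show. The step of a 2.1-fold lower number from compound 1 to compound 3 (0.33 log units; beyond the scatter) adds that a ring with 1 hetero atom and a ring of carbon only, in groups of equal heavy-atom count, do not read alike here, and nothing given explains this.

The compounds shown leave open whether a piperidine ring, with nitrogen as its hetero atom, would read like the oxygen-bearing ring. They also leave open how a longer chain between that ring and the amine nitrogen would read.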